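The source may report more compounds than this note shows. Statements on the series, on what has been measured and on what is new or still open speak of the compounds shown alone.

Values in an ADME assay on Vero cells (Chlorocebus sabaeus) for cytotoxicity, with a stated time of 72 h; a lower number here means a stronger inhibitor, a higher number a weaker inhibitor:
- compound 1 `O=C(CCN1CCN(c2ccc(C(F)(F)F)cc2)CC1)c1csc2ccccc12`: 237000 nM
- compound 2 `O=C(CCN1CCN(c2ccc(C(F)(F)F)cc2)CC1)c1csc2ccc(F)cc12`: 896000 nM
- compound 3 `O=C(CCN1CCN(c2ccc(Cl)cc2)CC1)c1csc2ccc(F)cc12`: not yet measured

Compound 2 holds the highest of the two numbers in this assay, at 896000 nM, and its nearest neighbour is compound 1 at 237000 nM. Compound 3 carries chloro in place of trifluoromethyl on an aromatic carbon, para to a large group: chloro in place of trifluoromethyl on an aromatic carbon. Within the data shown here, the one measured step, a 3.8-fold higher number from compound 1 to compound 2 (0.58 log units; beyond the scatter), is fluoro in place of hydrogen on an aromatic carbon, a different change at a different place. It is modest and beyond the scatter, so it offers a scale but no direction. Among the measured compounds shown here, no measured pair covers this exchange. With compound 2 at the top of so small a set, a modest move to a lower number is weakly expected. The expected change is a 1.6-fold lower number from compound 2 to compound 3 (0.21 log units; within the scatter). For compound 3 the estimated value is 550000 nM, with an expected range of 200000 nM to 1200000 nM.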

Compound 3, half-maximal inhibitory concentration: 246000 nM
For compound 3 the middle estimate is 2.2-fold (0.35 log units) above the measured one; low and high end bracket the measured number.
By their numbers in this assay, from the lowest: compounds 1 and 3 (each within the scatter of the next); then compound 2.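

In this assay, among these compounds, the change from 4-(trifluoromethyl)phenyl to 4-chlorophenyl gives a 3.6-fold lower number from compound 2 to compound 3 (0.56 log units; beyond the scatter), the first reading at this position on the aromatic carbon para to a large group. The number here therefore responds to this exchange as well as to the fluoro exchange elsewhere on the core, and the two steps, both modest, run in opposite directions, since the earlier one is a 3.8-fold higher number from compound 1 to compound 2 (0.58 log units; beyond the scatter).

With only one exchange shown at this position, it remains open how the number moves with other groups there, such as methoxy, nitrile or plain hydrogen. As far as these compounds go, it also remains open whether the same exchange gives a step of similar size and direction on the core of compound 1. No measurement is available to explain the step.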